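The source may report more compounds than this note shows. Statements on the series, on what has been measured and on what is new or still open speak of the compounds shown alone.

In an ADME assay on HepG2 cells (Homo sapiens) for cytotoxicity, read by MTT assay, with a stated time of 72 h (a lower number here means that less compound is tolerated, a higher number that more compound is tolerated), compound 2 (`CC(C)(C)Nc1nc2ccsc2c(=O)[nH]1`) gives 8400 nM, within the scatter of compound 1 (`CC(C)(C)Nc1nc2cc(-c3ccccc3)sc2c(=O)[nH]1`) at 12500 nM and of compound 3 (`Cc1cccc(-c2cc3nc(NC(C)(C)C)[nH]c(=O)c3s2)c1`) at 14100 nM. Compound 4 (`Cc1ccc(-c2csc3c(=O)[nH]c(NC(C)(C)C)nc23)cc1`) has 4-methylphenyl in place of hydrogen on an aromatic carbon of compound 2, two ring bonds from the ring sulfur: 4-methylphenyl in place of hydrogen on an aromatic carbon. The closest measured steps are a 1.7-fold higher number from compound 2 to compound 3 (0.22 log units; within the scatter) and a 1.5-fold lower number from compound 1 to compound 2 (0.17 log units; within the scatter), with a 1.1-fold higher number from compound 1 to compound 3 (0.05 log units; within the scatter) for the added methyl, and all are within the scatter. None of them involves the carbon substituted in compound 4, so they are only loose guides. In this assay, the expected change is a 1.5-fold higher number from compound 2 to compound 4 (0.17 log units; within the scatter), no step beyond the scatter. Compound 4 is estimated at 12500 nM, with an expected range of 6500 nM to 24000 nM.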

Compound 4, half-maximal cytotoxic concentration: 1400 nM
For compound 4 the middle estimate is 8.9-fold (0.95 log units) above the measured one, and the stated range ends above it.
By their numbers in this assay, from the lowest: compound 4; then compounds 2, 1 and 3 (each within the scatter of the next).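

In this assay, 4-methylphenyl in place of hydrogen on the aromatic carbon two ring bonds from the ring sulfur gives a 6.0-fold lower number from compound 2 to compound 4 (0.78 log units; beyond the scatter) and is the only step shown beyond the scatter. Substitution at the other carbon stays within it, with a 1.7-fold higher number from compound 2 to compound 3 (0.22 log units; within the scatter) as the nearest comparison, so this carbon tolerates less of the change on the evidence of these compounds. No measured evidence accounts for the shift.

As far as these compounds go, whether it follows from the ring or from its methyl stays open. Also open, from the compounds shown here alone, is what a carboxylic acid or an amine on this carbon would give.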